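A few compounds are considered here, and "the series" means these few. Any claim that something is new, unique, unknown or untested is made for them only; others in the source may bear on it.

Working notes on the series.

The read-out throughout is a functional assay on HeLa cells (Homo sapiens) for antiproliferative activity, read by MTT assay, with a stated time of 72 h; a lower number here means a stronger inhibitor, a higher number a weaker inhibitor. Compound 1 `O=C1O/C(=C\Cn2cnc3c(Cl)c(F)nc(F)c32)C(OCc2ccccc2)=C1OCc1ccccc1` gives only a limit in this assay, > 100000 nM, so its actual potency is not known from the run. This places compound 1 at the limit described in the limit of > 100000 nM in this assay, at which 1 of the 3 values shown sits. Compound 2 `O=C1NC(O)(CCn2cnc3cncc(Br)c32)C(OCc2ccccc2)=C1OCc1ccccc1` gives 77000 nM in this assay. Compound 3 `O=C1O/C(=C\Cn2cnc3ccn(C/C=C4\OC(=O)C(OCc5ccccc5)=C4OCc4ccccc4)c3c2=O)C(OCc2ccccc2)=C1OCc1ccccc1` gives 5600 nM in this assay, the only one of the three measured with a number clearly away from the weak end.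

The unmeasured member is compound 4 `O=C1O/C(=C\Cn2cnc3cncc(Br)c32)C(OCc2ccccc2)=C1OCc1ccccc1`. It differs from compound 1 by a group of 10 heavy atoms (6 carbon, 3 nitrogen, 1 bromine; one five-membered aromatic ring with 2 hetero atoms, one six-membered aromatic ring with 1 hetero atom) in place of a group of 12 heavy atoms (6 carbon, 3 nitrogen, 2 fluorine, 1 chlorine; one five-membered aromatic ring with 2 hetero atoms, one six-membered aromatic ring with 1 hetero atom), on a saturated chain carbon bound to a double-bonded chain carbon. Within the data shown here, no directly measured step of this kind exists in the set, so the expectation rests on the limit of compound 1 and on the numbers of compound 2 and compound 3.

The step of an at least 1.2-fold lower number from compound 1 to compound 4 (0.09 log units; that floor lies within the scatter) is expected to be small, if anything toward a weak but measurable inhibitor, since a reading at the limit cannot be improved upon downward except by leaving it. For compound 4 the estimate in this assay is 80000 nM, with a range from 20000 nM to 300000 nM, and a real chance that only a limit is reported.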

Compound 4, half-maximal inhibitory concentration: 15000 nM
Estimate against measurement, compound 4: 5.3-fold (0.73 log units) above; the measured number lies below the stated range.
By their numbers in this assay, from the lowest: compound 3; then compound 4; then compound 2. At a limit, above all of these: compound 1.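

In this assay, among these compounds, the exchange on a saturated chain carbon bound to a double-bonded chain carbon gives an at least 6.6-fold lower number from compound 1 to compound 4 (0.82 log units; beyond the scatter), the first step that can be read at all. The group of 10 heavy atoms (6 carbon, 3 nitrogen, 1 bromine) thus brings the compound off the limit seen with the group of 12 heavy atoms (6 carbon, 3 nitrogen, 2 fluorine, 1 chlorine), although both groups have the same ring types and the same counts of hydrogen-bond donors and acceptors. The step is only a floor and its true size stays unknown, because compound 1 gives a limit and not a number: the limit of > 100000 nM in this assay, at which 1 of the 4 values shown sits.

The compounds shown do not separate the bromine from the chlorine and the two fluorines as the source of the step. As far as these compounds go, whether an amine or a carboxylic acid in place of the bromine would keep this gain also stays open.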